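The compounds below may be only part of what the source reports. "The series", "measured", "known", "first", "only" and "open" are said of these compounds alone.

Measured so far:
- compound 1, `CN1CCC[C@H]1COc1cccnc1`: 0.15 nM
- compound 2, `CN1CCC[C@H]1COc1ccc(F)nc1`: 2.56 nM

In an assay on membranes from brain for displacement of a labelled ligand from Neuronal acetylcholine receptor; alpha4/beta2 (Rattus norvegicus) (a higher number here means a weaker inhibitor, a lower number a stronger inhibitor), compound 2 stands at the highest of the two numbers; its nearest neighbour is compound 1, reached by a 17-fold higher number from compound 1 to compound 2 (1.23 log units; beyond the scatter). Compound 3, `Cc1ccc(OC[C@@H]2CCCN2C)cn1`, differs from compound 2 by methyl in place of fluoro on an aromatic carbon. Within the data shown here, the only step that bears on this position is the one from compound 1 to compound 2, which was large. No methyl at this carbon has been measured, so the direction is open; the expected step of a 1.6-fold higher number from compound 2 to compound 3 (0.19 log units; within the scatter) is small, with wide uncertainty. For compound 3 the estimate in this assay is 4 nM, range 0.8 nM to 25 nM.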

Compound 3, inhibition constant: 1.26 nM
Compound 3: middle estimate off by 3.2-fold (0.50 log units), on the high side, within the range that was stated.
By their numbers in this assay, from the lowest: compound 1; then compound 3; then compound 2.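

In this assay methyl in place of hydrogen on the aromatic carbon next to the ring nitrogen gives an 8.4-fold higher number from compound 1 to compound 3 (0.92 log units; beyond the scatter) so the rise in number at this carbon is not confined to fluoro. Methyl in place of fluoro gives a 2.0-fold lower number from compound 2 to compound 3 (0.31 log units; beyond the scatter) so the two groups can be told apart, though both stay on the high side of hydrogen. Nothing available accounts for this order.

On these data alone, how a chloro group, an amine or a longer chain at this carbon would compare with hydrogen stays open. Also open, as far as these compounds go, is whether any group here can match hydrogen.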